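Swapping the Piperidine Ring for a Methylpiperazine

This account rests on a few compounds, and the source may have more. Where it says the series, first, only, none or still open, it means among the compounds named here.

In a functional assay on PC-3 cells (Homo sapiens) for antiproliferative activity, read by MTT assay, with a stated time of 72 h (on this read-out lower numbers stand for stronger inhibition and higher numbers for weaker inhibition), compound 2 `COc1cc2ncnc(N3CCc4ccccc43)c2cc1NC(=O)/C=C/CN1CCCCC1` gives 4180 nM, and compound 1 `COc1cc2ncnc(N3CCc4ccccc43)c2cc1NC(=O)C=C(C)C` gives 7840 nM; the step of a 1.9-fold lower number from compound 1 to compound 2 (0.27 log units; within the scatter) is within the scatter, so compound 2 stands beside compound 1 rather than apart from it. Compound 3 `COc1cc2ncnc(N3CCc4ccccc43)c2cc1NC(=O)/C=C/CN1CCN(C)CC1` differs from compound 2 by 4-methylpiperazin-1-yl in place of piperidin-1-yl on a saturated chain carbon bound to a double-bonded chain carbon. Within the data shown here, no measured step exchanges this ring; the only measured step, a 1.9-fold lower number from compound 1 to compound 2 (0.27 log units; within the scatter), alters the same chain elsewhere and stays within the scatter. A step of similar size, within the scatter, is therefore expected for a 1.1-fold higher number from compound 2 to compound 3 (0.03 log units; within the scatter). Compound 3 is estimated at 4500 nM, with an expected range from 1500 nM to 13000 nM.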

Compound 3, half-maximal inhibitory concentration: 9180 nM
For compound 3 the middle estimate is 2.0-fold (0.31 log units) below the measured one, and the stated range covers the measured number.
By their numbers in this assay, from the lowest: compounds 2, 1 and 3 (each within the scatter of the next, the first and the last beyond it).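

In this assay, among these compounds, the ring itself is exchanged here for the first time, and 4-methylpiperazin-1-yl in place of piperidin-1-yl on this saturated chain carbon gives a 2.2-fold higher number from compound 2 to compound 3 (0.34 log units; beyond the scatter), a modest step. Set against the 2-methylprop-1-en-1-yl group, the full 3-(4-methylpiperazin-1-yl)prop-1-en-1-yl group gives a 1.2-fold higher number from compound 1 to compound 3 (0.07 log units; within the scatter), so compound 3 stands level with compound 1. Nothing available explains the step from the piperidine to the methylpiperazine ring. On these data alone, whether a morpholine ring or an open dimethylamino group at this carbon would read closer to compound 2 or to compound 3 remains open.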